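From 3-fluorophenyl to 4-fluorophenyl on a shared core

The source may report more compounds than this note shows. Statements on the series, on what has been measured and on what is new or still open speak of the compounds shown alone.

- compound 1 `CCOC(=O)CC1C(C(=O)OCC)=C(N)Oc2ccc(-c3cc(OC)cc(OC)c3)cc21` gives 10700 nM
- compound 2 `CCOC(=O)CC1C(C(=O)OCC)=C(N)Oc2ccc(-c3ccccc3F)cc21` gives 73000 nM
- compound 3 `CCOC(=O)CC1C(C(=O)OCC)=C(N)Oc2ccc(-c3cccc(F)c3)cc21` gives 76400 nM

These values all come from a functional assay on HL-60 cells (Homo sapiens) for cytotoxicity, read by CellTiter-Blue, with a stated time of 48 h; a lower number here means a stronger inhibitor, a higher number a weaker inhibitor. The three compounds share one core and differ only in the aromatic group attached to it. Compound 3 stands level with compound 2, within the scatter, and its number lies clearly above that of compound 1 .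

The next compound, compound 4 `CCOC(=O)CC1C(C(=O)OCC)=C(N)Oc2ccc(-c3ccc(F)cc3)cc21`, carries 4-fluorophenyl in place of 3-fluorophenyl on an aromatic carbon. The atoms stay the same and only their connection changes.

The closest guide is a 1.0-fold higher number from compound 2 to compound 3 (0.02 log units; within the scatter), a change between two fluorophenyl groups that stayed within the scatter. The two larger steps, a 6.8-fold higher number from compound 1 to compound 2 (0.83 log units; beyond the scatter) and a 7.1-fold higher number from compound 1 to compound 3 (0.85 log units; beyond the scatter), were modest, but each replaced 3,5-dimethoxyphenyl, which is a much bigger change. Going by these compounds, no step beyond the scatter is therefore expected in this assay, although this rests on a single comparison and 4-fluorophenyl itself is untested. The estimated result is a 1.1-fold lower number from compound 3 to compound 4 (0.03 log units; within the scatter). Compound 4 is expected to give about 72000 nM, within an estimated range of 38000 nM to 130000 nM.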

Compound 4, half-maximal inhibitory concentration: 72100 nM
Estimate against measurement, compound 4: 1.0-fold (0.00 log units) below, and the stated range covers the measured number.
By their numbers in this assay, from the lowest: compound 1; then compounds 4, 2 and 3 (each within the scatter of the next).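

In this assay, 4-fluorophenyl in place of 3-fluorophenyl gives a 1.1-fold lower number from compound 3 to compound 4 (0.03 log units; within the scatter), and 4-fluorophenyl in place of 2-fluorophenyl gives a 1.0-fold lower number from compound 2 to compound 4 (0.01 log units; within the scatter), so all three fluorophenyl compounds now lie within the scatter of one another and the place of the fluorine on this ring does not separate them. The third fluorophenyl group also shows the same gap from the 3,5-dimethoxyphenyl group as the other two, with a 6.7-fold higher number from compound 1 to compound 4 (0.83 log units; beyond the scatter), so among these four compounds only compound 1 stands apart, and it has the lowest number. Nothing measured here explains either the lack of separation among the fluorophenyl groups or the gap to 3,5-dimethoxyphenyl.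

The compounds shown leave open whether a single methoxy group on the phenyl ring would already give a number close to that of compound 1, or whether both methoxy groups of 3,5-dimethoxyphenyl are needed. They also leave open how a phenyl ring carrying an amine or a carboxylic acid would read at this position, and whether any such group could reach a number well below that of compound 1.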